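Swapping the carbamate end group on the side chain

The source may report more compounds than this note shows. Statements on the series, on what has been measured and on what is new or still open speak of the compounds shown alone.

Measured so far:
- compound 1, `COc1cc2ncnc(-n3nc(-c4ccccn4)nc3N)c2cc1OCc1ccccc1`: 8600 nM
- compound 2, `COc1cc2ncnc(-n3nc(-c4ccccn4)nc3N)c2cc1OCCCCNC(=O)OC(C)(C)C`: 800 nM

In an assay on MCF7 cells for inhibition of Serine-protein kinase ATM (Homo sapiens), read by immunofluorescence, with a stated time of 1 h (on this read-out lower numbers stand for stronger inhibition and higher numbers for weaker inhibition), compound 2 gives the lowest of the two numbers seen so far. Going by the values given here, its nearest neighbour is compound 1, and the only measured step is an 11-fold lower number from compound 1 to compound 2 (1.03 log units; beyond the scatter), a large gain that came from replacing the phenyl on the side chain with a carbamate-bearing chain.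

Compound 3, `CCCCCCOC(=O)NCCCOc1cc2c(-n3nc(-c4ccccn4)nc3N)ncnc2cc1OC`, keeps that carbamate-bearing chain but alters its end: (hexyloxycarbonyl)amino in place of ((tert-butoxycarbonyl)amino)methyl on a saturated chain carbon, three bonds along the chain from an oxygen on an aromatic ring. The measured step from compound 1 to compound 2 bears on this only loosely, since it exchanged a phenyl for a carbamate chain, whereas here one carbamate is exchanged for another of similar size, with the same count of donors and acceptors. Among the compounds with values here, no measured pair shows what changing the carbamate ester group alone does. For compound 3 the expected step is therefore no change at the digits printed from compound 2 to compound 3 (within the scatter), that is, no change beyond the scatter. Compound 3 is estimated at 800 nM, within a range of 300 nM to 2500 nM.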

Compound 3, half-maximal inhibitory concentration: 28600 nM
Compound 3: middle estimate off by 36-fold (1.55 log units), on the low side; the whole stated range lies below it.
By their numbers in this assay, from the lowest: compound 2; then compound 1; then compound 3.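

In this assay, the far end of this side chain turns out to matter far more than its counts of hydrogen-bond donors and acceptors suggest: (hexyloxycarbonyl)amino in place of ((tert-butoxycarbonyl)amino)methyl gives a 36-fold higher number from compound 2 to compound 3 (1.55 log units; beyond the scatter), although those counts are identical and neither group has a ring or a net charge. A carbamate-bearing chain therefore does not lower the number on its own, as compound 2 does relative to compound 1, since the comparison with the phenyl-ended side chain now runs the other way, with a 3.3-fold higher number from compound 1 to compound 3 (0.52 log units; beyond the scatter). No measurement available here accounts for this reversal.

The change also removes the methyl link carried by the leaving group, so the chain length and the carbamate ester group differ together, and the compounds shown do not separate the contribution of each. Still open, on these data alone, are how a tert-butyl carbamate on the chain of compound 3 or a hexyl carbamate on the chain of compound 2 would read, and whether a free amine at the chain end would give a lower or higher number.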